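Swapping Phenyl for Naphthalen-2-yl on a Sulfonyl Sulfur

A few compounds are considered here, and "the series" means these few. Any claim that something is new, unique, unknown or untested is made for them only; others in the source may bear on it.

Compound 1 `CC1=C(CC(=O)NCCN2CCCC2)c2cc(F)ccc2/C1=C\c1nc2ccccc2s1` gives 4940 nM
Compound 2 `CC1=C(CC(=O)N(C)CCN(C)S(=O)(=O)c2ccccc2)c2cc(F)ccc2/C1=C\c1ccc([S+](C)[O-])cc1` gives 8200 nM

In a functional assay on PC-3 cells (Homo sapiens) for inhibition, read by CellTiter-Glo, with a stated time of 72 h (a higher number here means that more compound is tolerated, a lower number that less compound is tolerated), compound 2 reads (8200 nM), within the usual scatter of compound 1 (4940 nM). Compound 3 `CC1=C(CC(=O)N(C)CCN(C)S(=O)(=O)c2ccc3ccccc3c2)c2cc(F)ccc2/C1=C\c1ccc([S+](C)[O-])cc1` differs from compound 2 by a single change (naphthalen-2-yl in place of phenyl on a sulfonyl sulfur): naphthalen-2-yl in place of phenyl on a sulfonyl sulfur. Within the data shown here, no measured pair shows what this swap does, so any forecast is tentative. An estimated step of a 1.6-fold lower number from compound 2 to compound 3 (0.21 log units; within the scatter) is expected, modest and toward a lower number, perhaps no larger than the scatter. Compound 3 is expected at 5000 nM (expected range 1800 nM to 12000 nM).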

Compound 3, half-maximal cytotoxic concentration: 7520 nM
The estimate for compound 3 lay 1.5-fold (0.18 log units) below the measured number, within the range that was stated.
By their numbers in this assay, from the lowest: compounds 1, 3 and 2 (each within the scatter of the next).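

In this assay, among these compounds, putting naphthalen-2-yl in place of phenyl on a sulfonyl sulfur gives a 1.1-fold lower number from compound 2 to compound 3 (0.04 log units; within the scatter), the first measured pair for this swap. At this one position, then, the second aromatic ring leaves the reading within the scatter. Nothing measured here bears on the reason for this result.

Still open, from the compounds shown here alone, is whether a small methyl or a phenyl carrying a carboxylic acid on the sulfonyl sulfur would move the number beyond the scatter. A single pair also cannot show whether this holds on other versions of the shared core.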